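Secondary amide to azetidine: step from compound 2 to 4

A few compounds are considered here, and "the series" means these few. Any claim that something is new, unique, unknown or untested is made for them only; others in the source may bear on it.

Of the compounds shown here, three from the same series have been tested in a functional assay on the whole organism with Rattus norvegicus as the target, at a dose of 20 mg/kg by the oral route; a lower number here means less inhibition, a higher number more inhibition at the dose given (going by the name of the read-out). Compound 1 `NC(=O)/C=C1\CCc2c(Cl)cccc21` gives 58%. Compound 2 `CC(C)NC(=O)/C=C1\CCc2ccc(F)cc21` gives 71%, the highest of the three numbers, and its step down to compound 1 lies beyond the scatter. Compound 3 `NC(=O)/C=C1\CCc2cc(F)ccc21` gives 42%, the furthest from compound 2, again beyond the scatter. No pair among these three differs in only one place, so no single step can be read from them.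

Compound 4 `O=C(/C=C1\CCc2ccc(F)cc21)N1CCC1` has not yet been measured. It differs from compound 2 in one place: azetidin-1-yl in place of isopropylamino on a carbonyl carbon. Going by the values given here, the amide hydrogen of compound 2 is gone in compound 4, and nothing among the measured compounds tells what that does in this assay . A modest fall is expected for compound 4, though the range is wide, and the step of a number 13 percentage points lower from compound 2 to compound 4 (beyond the scatter) is the estimate.

Compound 4 is expected to give 58% in this assay , with a range from 30% to 80%.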

Compound 4, a percentage reported as inhibition, in the whole organism at one dose (the size of the read-out at that dose, not a potency): 0%
Estimate against measurement, compound 4: 58 percentage points above; measured number below the stated range.
By their numbers in this assay, from the lowest: compound 4; then compound 3; then compound 1; then compound 2.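

Going by these compounds alone, the first comparison at this position, the carbonyl carbon, shows that it is highly sensitive in this assay: azetidin-1-yl in place of isopropylamino gives a number 71 percentage points lower from compound 2 to compound 4 (beyond the scatter), and compound 4 gives 0% at the dose tested. The two groups have the same number of heavy atoms, yet the change removes the amide hydrogen and adds a four-membered ring in one step, so a swap of equal size is enough to take the read-out to the bottom of the series. Nothing among the data shown accounts for this step.

The compounds shown leave open whether the loss of the amide hydrogen or the presence of the ring matters more. Dimethylamino, which has no amide hydrogen and no ring, and cyclobutylamino, which keeps the hydrogen and has a ring, would separate the two.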